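Dimethoxy styryl lactones: expected growth inhibition of compound 4

The source may hold more compounds than are shown below. What is called first, only, known or untested is meant among the compounds shown, and "the series" means these compounds.

Measured so far in a functional assay on U-251 cells (Homo sapiens) for inhibition, read by sulforhodamine B assay, with a stated time of 48 h; a higher number here means a weaker inhibitor of growth, a lower number a stronger inhibitor of growth:
compound 1 `O=C1C=CCC(/C=C/c2ccc(C(F)(F)F)cc2)O1`: 36.8 uM
compound 2 `COc1ccc(/C=C/C2CC=CC(=O)O2)cc1`: 20.6 uM
compound 3 `COc1ccc(/C=C/C2CC=CC(=O)O2)c(OC)c1`: 4.6 uM

Compound 2 holds the second highest of the three numbers; compound 1 lies nearest, a 1.8-fold lower number from compound 1 to compound 2 (0.25 log units; within the scatter), and compound 3 furthest, a 4.5-fold lower number from compound 2 to compound 3 (0.65 log units; beyond the scatter).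

Compound 4 `COc1ccc(/C=C/C2CC=CC(=O)O2)cc1OC` differs from compound 2 by methoxy in place of hydrogen on an aromatic carbon. Among the measured compounds shown here, the one step that bears on this is the same change at another place: the methoxy in place of hydrogen on an aromatic carbon gave a 4.5-fold lower number from compound 2 to compound 3 (0.65 log units; beyond the scatter). Here the entering methoxy sits ortho to a methoxy group and meta to a group of 9 heavy atoms, so the size of the step is uncertain, but a lower number is expected because of a 4.5-fold lower number from compound 2 to compound 3 (0.65 log units; beyond the scatter). The estimated step is a 2.6-fold lower number from compound 2 to compound 4 (0.41 log units; beyond the scatter). Compound 4 is expected to give about 8 uM, with a likely range from 3 uM to 20 uM.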

Compound 4, concentration for growth inhibition (reported as GI): 23.9 uM
Compound 4: middle estimate off by 3.0-fold (0.48 log units), on the low side, and the stated range ends below it.
By their numbers in this assay, from the lowest: compound 3; then compounds 2, 4 and 1 (each within the scatter of the next).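

In this assay, methoxy in place of hydrogen, ortho to a methoxy group and meta to a group of 9 heavy atoms, gives a 1.2-fold higher number from compound 2 to compound 4 (0.06 log units; within the scatter) while the same change at the place it occupies in compound 3 gives a 4.5-fold lower number from compound 2 to compound 3 (0.65 log units; beyond the scatter). Across these two steps, the outcome of adding methoxy therefore depends on where it enters. Nothing at hand accounts for this difference.

Open, from the compounds shown here alone, is whether an amine or a longer chain at this place would read like hydrogen and methoxy do here. Also open, going by these compounds, is whether the dependence on place holds for a group other than methoxy.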